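Methyl scan on the fused pyridine core: two positions compared

A few compounds are considered here, and "the series" means these few. Any claim that something is new, unique, unknown or untested is made for them only; others in the source may bear on it.

Compound 1 `Oc1cc(-c2ccc(Cl)cc2)nc2ncccc12` gives 8320 nM in a functional assay on MDA-N cells (Homo sapiens); on this read-out higher numbers stand for weaker inhibition of growth and lower numbers for stronger inhibition of growth. Among the measured compounds shown here, compound 2 `Cc1cnc2nc(-c3ccc(Cl)cc3)cc(O)c2c1` carries one extra methyl and gives 562 nM in this assay; the step of a 15-fold lower number from compound 1 to compound 2 (1.17 log units; beyond the scatter) is the only single-point change measured in this set. The change itself: methyl in place of hydrogen on an aromatic carbon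

Compound 3 `COc1ccccc1-c1cc(O)c2cccnc2n1` rests on a different core; how it differs from compound 1 is not broken down here. In this assay compound 3 gives 20000 nM, the highest of the three numbers, and the gap to compound 1 lies beyond the scatter.

Compound 4 `COc1ccccc1-c1cc(O)c2c(C)ccnc2n1` is not yet measured. It relates to compound 3 by the same kind of change as compound 2 to compound 1, but at a different place: here the methyl sits ortho to a fused ring, meta to a fused ring and opposite the ring nitrogen, whereas in compound 2 it sits two atoms from the ring nitrogen, meta to a fused ring and para to a fused ring. methyl in place of hydrogen on an aromatic carbon

Beside a 15-fold lower number from compound 1 to compound 2 (1.17 log units; beyond the scatter), a smaller step of a 2.9-fold lower number from compound 3 to compound 4 (0.46 log units; beyond the scatter) is expected, since the place of the methyl is not the same and the cores differ. For compound 4 the estimate in this assay is 7000 nM, between 2000 nM and 20000 nM.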

Compound 4, concentration for 50% growth inhibition: 8320 nM
Beside the measured number, compound 4's estimate is 1.2-fold (0.08 log units) below it; the measured number falls inside the stated range.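

In this assay the methyl in place of hydrogen on an aromatic carbon again moves the number the same way, with a modest step: a 2.4-fold lower number from compound 3 to compound 4 (0.38 log units; beyond the scatter). The direction carries over from one core to the other in these two pairs, but the size of the step does not: the same change on two cores in this assay, a 15-fold lower number (1.17 log units; beyond the scatter) from compound 1 to compound 2 and a 2.4-fold lower number (0.38 log units; beyond the scatter) from compound 3 to compound 4, 6.2-fold (0.79 log units) apart, beyond the scatter of two such steps. The two pairs differ both in the core and in the place of the methyl, which in compound 4 is ortho to a fused ring and opposite the ring nitrogen, so they cannot show which of the two sets the size of the step, and two pairs make no rule for the series.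

Going by these compounds, it remains open whether the methyl opposite the ring nitrogen would give a comparable step on the core of compound 1, and whether the place it holds in compound 2 would do so on the core of compound 3. Also open, on these data alone, is how an ethyl group, a longer chain or an amine would behave at either place.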